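Amide side chain exchange in the series

The compounds below may be only part of what the source reports. "The series", "measured", "known", "first", "only" and "open" are said of these compounds alone.

In a functional assay on HepG2 cells (Homo sapiens), read by MTT assay, with a stated time of 48 h (a higher number here means a weaker inhibitor, a lower number a stronger inhibitor), compound 1 (`CCN(CC)CCNC(=O)c1ccc(C(CC)(CC)c2ccc(OCC(=O)C(C)(C)C)c(C)c2)n1CC`) gives 620 nM, compound 2 (`CCn1c(C(=O)NCCCN(C)C)ccc1C(CC)(CC)c1ccc(OCC(=O)C(C)(C)C)c(C)c1`) gives 960 nM and compound 3 (`CCn1c(C(=O)NCCCN(C)C)ccc1C(CC)(CC)c1ccc(OCC(O)C(C)(C)C)c(C)c1`) gives 360 nM. Compound 3 therefore lies within the scatter of compound 1 and clear of compound 2. Compound 4 (`CCn1c(C(=O)N(C)CCC#N)ccc1C(CC)(CC)c1ccc(OCC(O)C(C)(C)C)c(C)c1`) carries (2-cyanoethyl)(methyl)amino in place of (3-(dimethylamino)propyl)amino on a carbonyl carbon. Two measured steps offer limited guidance. The change a 1.5-fold higher number from compound 1 to compound 2 (0.19 log units; within the scatter) alters the amine side chain, while a 2.7-fold lower number from compound 2 to compound 3 (0.43 log units; beyond the scatter) is modest and concerns a different group. Neither replaces an amine side chain with a nitrile-bearing one, so the expectation is uncertain. The expected change, towards a higher number, is a 2.8-fold higher number from compound 3 to compound 4 (0.44 log units; beyond the scatter). Compound 4 is estimated at 1000 nM, with an expected range of 200 nM to 5000 nM.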

Compound 4, half-maximal inhibitory concentration: > 50000 nM
Compound 4 ended at the assay's limit; the forecaster's own chance of this, stated with the estimate: 10%; middle value at least 50-fold (1.69 log units) from the limit.
By their numbers in this assay, from the lowest: compounds 3, 1 and 2 (each within the scatter of the next, the first and the last beyond it). At a limit, above all of these: compound 4.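

The side chain on this carbonyl carbon is far from indifferent: (2-cyanoethyl)(methyl)amino in place of (3-(dimethylamino)propyl)amino gives an at least 130-fold higher number from compound 3 to compound 4 (2.14 log units; beyond the scatter). Within the data shown here, the one earlier change at this place, from one amine side chain to another, stayed small: a 1.5-fold higher number from compound 1 to compound 2 (0.19 log units; within the scatter). The value of compound 4 is a limit of the assay, not a number: the limit of > 50000 nM in this assay, at which 1 of the 4 values shown sits.

Open, as far as these compounds go, is which part of the exchange carries the loss: the nitrile, the methyl on the amide nitrogen, or the absent dimethylamino group. A 2-cyanoethylamino group and a (3-(dimethylamino)propyl)(methyl)amino group would separate these.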